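A few compounds are considered here, and "the series" means these few. Any claim that something is new, unique, unknown or untested is made for them only; others in the source may bear on it.

Compound 3 `COc1cc(-n2cnc3ccc(-c4ccccc4Cl)cc32)cc(OC)c1OC` gives in a functional assay on SGC-7901 cells (Homo sapiens) for antiproliferative activity, read by MTT assay, with a stated time of 72 h (a higher number here means a weaker inhibitor, a lower number a stronger inhibitor), only a limit, > 10000 nM, which is a limit of the assay rather than a number, as the evidence shows (the limit of > 10000 nM in this assay, at which 1 of the 3 values shown sits). Compound 1 `COc1cc(-n2cnc3ccc(-c4ccc(Cl)cc4)cc32)cc(OC)c1OC` gives 1270 nM in this assay, and compound 2 `COc1cccc(-c2ccc3ncn(-c4cc(OC)c(OC)c(OC)c4)c3c2)c1` gives 3310 nM. Compound 4 `COc1ccc(-c2ccc3ncn(-c4cc(OC)c(OC)c(OC)c4)c3c2)cc1F` differs from compound 3 in one place: 3-fluoro-4-methoxyphenyl in place of 2-chlorophenyl on an aromatic carbon. Going by the values given here, two measured steps bear on this change, namely an at least 7.8-fold higher number from compound 1 to compound 3 (0.89 log units; beyond the scatter) and an at least 3.0-fold higher number from compound 2 to compound 3 (0.48 log units; beyond the scatter), both of which lead into the 2-chlorophenyl that compound 4 gives up. Moving away from that group, a lower number, beyond the scatter, is expected for compound 4, with a step estimated at an at least 5.0-fold lower number from compound 3 to compound 4 (0.69 log units; beyond the scatter). Compound 4 is therefore expected to give about 2000 nM, between 700 nM and 6000 nM.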

Compound 4, half-maximal inhibitory concentration: 430 nM
The estimate for compound 4 lay 4.7-fold (0.67 log units) above the measured number; the whole stated range lies above it.
By their numbers in this assay, from the lowest: compound 4; then compound 1; then compound 2. At a limit, above all of these: compound 3.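

On this aromatic carbon, 3-fluoro-4-methoxyphenyl makes compound 4 the strongest of the four in this assay, with a 3.0-fold lower number from compound 1 to compound 4 (0.47 log units; beyond the scatter) and a 7.7-fold lower number from compound 2 to compound 4 (0.89 log units; beyond the scatter). Compound 3 gives only a limit of the assay, > 10000 nM. Even so, the largest change at this position can be read as an at least 23-fold lower number from compound 3 to compound 4 (1.36 log units; beyond the scatter), and it shows that a change here can lower the number well past that of compound 1.

As far as these compounds go, what 3-fluorophenyl or 4-methoxyphenyl alone would give remains open, so the fluoro and methoxy parts of the new group cannot be separated. An amine or a carboxylic acid on this ring also remains an open case.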